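Series notes: phenethyl for 4-ethylphenyl at compound 2

The source may report more compounds than this note shows. Statements on the series, on what has been measured and on what is new or still open speak of the compounds shown alone.

Four compounds share one core. Compound 1 `Nc1cccc(-c2cn3nc(-c4cccs4)sc3n2)c1` carries no amide side chain; compound 2 `C=C(Br)C(=O)Nc1cccc(-c2cn3nc(-c4ccc(CC)cc4)sc3n2)c1` and compound 3 `C=C(Br)C(=O)Nc1cccc(-c2cn3c(-c4ccccc4)csc3n2)c1` carry it on the same aniline, and compound 4 `C=C(Br)C(=O)Nc1cccc(-c2cn3nc(CCc4ccccc4)sc3n2)c1` keeps that side chain while the group on the bicyclic core is changed.

In a functional assay on HeLa cells (Homo sapiens) for inhibition, read by cell counting, with a stated time of 4 days (a higher number here means a weaker inhibitor, a lower number a stronger inhibitor), compound 1 gives > 250000 nM, which is a limit of the assay and not a number; of the three values shown, one sits at this limit (the limit of > 250000 nM in this assay, at which 1 of the 3 values shown sits). In the same assay compound 2 gives 3200 nM, the lowest of the two numbered values, and compound 3 gives 3400 nM, which lies within the usual scatter of compound 2, so no order between the two can be read.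

Compound 4 differs from compound 2 in one place: phenethyl in place of 4-ethylphenyl on an aromatic carbon. Among the compounds with values here, no measured step of this kind is available, so the direction is taken from the two values within scatter for compounds 2 and 3, which suggest that changes on this side of the core tolerate some variation. A modest step in the weaker direction is expected, as a 1.7-fold higher number from compound 2 to compound 4 (0.24 log units; within the scatter). Compound 4 is therefore estimated at 5500 nM, with a range from 1500 nM to 20000 nM.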

Compound 4, half-maximal inhibitory concentration: 3300 nM
Estimate against measurement, compound 4: 1.7-fold (0.22 log units) above, and the stated range covers the measured number.
By their numbers in this assay, from the lowest: compounds 2, 4 and 3 (each within the scatter of the next). At a limit, above all of these: compound 1.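

In this assay, within the data shown here, the only one-place step is a 1.0-fold higher number from compound 2 to compound 4 (0.01 log units; within the scatter), for phenethyl in place of 4-ethylphenyl on an aromatic carbon of the five-membered aromatic ring. Compound 2 and compound 4 have the same atoms joined differently, with the six-membered aromatic ring attached directly in compound 2 and through a chain in compound 4, and this change gives no readable difference at this position. Nothing measured here bears on why the two compounds cannot be told apart in this cell read-out.

Going by these compounds, how far this position accepts groups of another kind stays open, since phenethyl and 4-ethylphenyl are both all-carbon groups with an aromatic ring, and an amine, a carboxylic acid or a longer chain at this carbon would test that. On these data alone, compound 1 differs from compound 2 in more than one place, so the contribution of the amide side chain on the aniline also stays open.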